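Adding a Third Fluorine to Compound 1

The source may hold more compounds than are shown below. What is called first, only, known or untested is meant among the compounds shown, and "the series" means these compounds.

Compound 1 `COc1cccc2c1c(C(=O)/C=C(\O)C(=O)O)cn2Cc1cc(F)ccc1F` is the parent of this small set. In an ADME assay on MT4 cells (Homo sapiens) for cytotoxicity, read by MTT assay (a higher number here means that more compound is tolerated, a lower number that less compound is tolerated), compound 1 gives 46200 nM, the highest of the three numbers, although both neighbours lie within the scatter of it: compound 2 `CCOC(=O)/C(O)=C/C(=O)c1cn(Cc2ccc(F)c(F)c2F)c2cccc(OC)c12` gives 42700 nM and compound 3 `CCOC(=O)/C(O)=C/C(=O)c1cn(Cc2cc(F)ccc2F)c2cccc(OC)c12` gives 41200 nM. Two single changes have been measured. Putting ethyl in place of hydrogen on an oxygen next to a carbonyl group gives a 1.1-fold lower number from compound 1 to compound 3 (0.05 log units; within the scatter), and putting 2,5-difluorophenyl in place of 2,3,4-trifluorophenyl gives a 1.0-fold lower number from compound 2 to compound 3 (0.02 log units; within the scatter). Neither moves the read-out beyond the scatter.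

Compound 4 `COc1cccc2c1c(C(=O)/C=C(\O)C(=O)O)cn2Cc1c(F)ccc(F)c1F` differs from compound 1 by one added atom: fluoro in place of hydrogen on an aromatic carbon. Read one bond further out, the change is from 2,5-difluorophenyl to 2,3,6-trifluorophenyl, so the step that bears on it is the one from compound 2 to compound 3, which exchanged two fluorination patterns of the same ring and stayed within the scatter. The ethyl step from compound 1 to compound 3 concerns a different part of the molecule and says nothing about this position. Going by the values given here, no measured step therefore argues for a change in this assay, and compound 4 is expected to sit within the scatter of compound 1, a 1.1-fold lower number from compound 1 to compound 4 (0.02 log units; within the scatter). The estimate for compound 4 is 44000 nM, with a range from 24000 nM to 80000 nM.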

Compound 4, half-maximal cytotoxic concentration: 49400 nM
Beside the measured number, compound 4's estimate is 1.1-fold (0.05 log units) below it, within the range that was stated.
By their numbers in this assay, from the lowest: compounds 3, 2, 1 and 4 (each within the scatter of the next).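

Fluoro in place of hydrogen on this aromatic carbon, ortho to a fluoro group and ortho to a large group, gives in this assay a 1.1-fold higher number from compound 1 to compound 4 (0.03 log units; within the scatter), so the added fluorine leaves the read-out within the scatter. The earlier ring step, between compound 2 and compound 3, compared two fluorination patterns in compounds that both carry the ethyl group, whereas this step adds a single fluorine to compound 1, which carries hydrogen on that oxygen, and so extends the same reading to the form without ethyl. Nothing at hand accounts for this flat result or shows how this position behaves in any other setting.

The compounds shown hold only hydrogen or fluoro at this carbon, which leaves open whether chloro, methoxy or an amine there would stay within the scatter of compound 1 in this assay. They also leave open whether the 2,3,6-trifluorophenyl group would read the same in a compound carrying the ethyl group, or with a longer chain in its place.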